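This account rests on a few compounds, and the source may have more. Where it says the series, first, only, none or still open, it means among the compounds named here.

Three compounds share one core and differ only in the group on an aromatic carbon. Compound 1 `Cc1cccc(CN2CC=C(CCC(=O)NO)C2=O)c1` gives 2500 nM in a functional assay on NCI-H23 cells (Homo sapiens) for inhibition, read by sulforhodamine B assay; a lower number here means a stronger inhibitor of growth, a higher number a weaker inhibitor of growth. Compound 2 `O=C(CCC1=CCN(Cc2cccc(Br)c2)C1=O)NO` gives 2500 nM, and compound 3 `O=C(CCC1=CCN(Cc2cccc(Cl)c2)C1=O)NO` gives 2500 nM, so compound 3 stands level with compounds 1 and 2 at the digits shown. The steps of no change at the digits printed from compound 1 to compound 2 (within the scatter), no change at the digits printed from compound 1 to compound 3 (within the scatter) and no change at the digits printed from compound 2 to compound 3 (within the scatter) show that exchanging these groups moves nothing beyond the scatter. Compound 4 `N#Cc1cccc(CN2CC=C(CCC(=O)NO)C2=O)c1` carries cyano in place of chloro on an aromatic carbon. Within the data shown here, no measured step covers a cyano group, but since every exchange at this carbon left the reading unchanged, the expected step is no change at the digits printed from compound 3 to compound 4 (within the scatter), nothing beyond the scatter. Compound 4 is therefore estimated at 2500 nM in this assay, between 1200 nM and 5500 nM.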

Compound 4, concentration for 50% growth inhibition: 4080 nM
For compound 4 the middle estimate is 1.6-fold (0.21 log units) below the measured one; the range from low to high includes it.
By their numbers in this assay, from the lowest: compounds 1, 2, 3 and 4 (each within the scatter of the next).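

In this assay, cyano in place of the earlier groups on this aromatic carbon gives a 1.6-fold higher number from compound 3 to compound 4 (0.21 log units; within the scatter), a 1.6-fold higher number from compound 2 to compound 4 (0.21 log units; within the scatter) and a 1.6-fold higher number from compound 1 to compound 4 (0.21 log units; within the scatter). The tolerance seen among methyl, bromo and chloro therefore extends to a group with a triple bond and a hydrogen-bond acceptor, which none of those three carries. Nothing available explains why these four groups read alike.

As far as these compounds go, whether an amine, a carboxylic acid or a longer chain on this carbon would move the reading beyond the scatter remains open. So does whether these same groups would read alike on another carbon of the ring.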